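Swapping Trifluoromethyl for Methanesulfonamido on Compound 3

This account rests on a few compounds, and the source may have more. Where it says the series, first, only, none or still open, it means among the compounds named here.

Of the compounds shown here, three built on the shared core have been measured in an assay for binding affinity to dual specificity mitogen-activated protein kinase kinase 4 (Homo sapiens), read by KINOMEscan, tested at 100 nM; on this read-out lower numbers stand for a stronger effect and higher numbers for a weaker effect at the one concentration tested. Compound 1 `CCCS(=O)(=O)Nc1ccc(F)c(C(=O)c2n[nH]c3ncc(-c4cccc(C)c4)cc23)c1F` gives 15%, compound 2 `CCCS(=O)(=O)Nc1ccc(F)c(C(=O)c2n[nH]c3ncc(-c4cccc(O)c4)cc23)c1F` gives 2.2%, and compound 3 `CCCS(=O)(=O)Nc1ccc(F)c(C(=O)c2n[nH]c3ncc(-c4ccc(C(F)(F)F)cc4)cc23)c1F` gives 29%. Compound 3 stands highest of the three: its nearest neighbour is compound 1, and the gap a number 14 percentage points higher from compound 1 to compound 3 (beyond the scatter) lies beyond the scatter, as does a number 26.8 percentage points higher from compound 2 to compound 3 (beyond the scatter).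

Compound 4 `CCCS(=O)(=O)Nc1ccc(F)c(C(=O)c2n[nH]c3ncc(-c4ccc(NS(C)(=O)=O)cc4)cc23)c1F` differs from compound 3 in one place: methanesulfonamido in place of trifluoromethyl on an aromatic carbon. Of the measured steps, a number 12.8 percentage points lower from compound 1 to compound 2 (beyond the scatter) is the closest in kind, since it also exchanged a group with no donors for one carrying a donor on the same aromatic ring, and it lowered the number. The two steps leading to compound 3, a number 14 percentage points higher from compound 1 to compound 3 (beyond the scatter) and a number 26.8 percentage points higher from compound 2 to compound 3 (beyond the scatter), show that this ring position moves the read-out by modest amounts. A modest fall from compound 3 to compound 4 is therefore expected, a number 17 percentage points lower from compound 3 to compound 4 (beyond the scatter). Compound 4 is estimated at 12% in this assay, between 3% and 32%.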

Compound 4, a percentage reported as activity, at one concentration (the size of the read-out at that concentration, not a potency): 0.85%
For compound 4 the middle estimate is 11.2 percentage points above the measured one; the whole stated range lies above it.
By their numbers in this assay, from the lowest: compounds 4 and 2 (each within the scatter of the next); then compound 1; then compound 3.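

In this assay, the step of a number 28.2 percentage points lower from compound 3 to compound 4 (beyond the scatter) shows that a group in this place need not leave the number high, as compound 3 alone had suggested, since the change here is confined to the group on the ring. The same holds against a number 14.2 percentage points lower from compound 1 to compound 4 (beyond the scatter), whereas a number 1.4 percentage points lower from compound 2 to compound 4 (within the scatter) leaves 4-(methanesulfonamido)phenyl and 3-hydroxyphenyl indistinguishable, so among these four compounds the two whose aryl group carries a hydrogen-bond donor sit at the low end, and none goes against this. Nothing available gives a reason for the step.

Still open, on these data alone, is whether the amide hydrogen or the sulfonyl part of methanesulfonamido accounts for the fall, which an amine or a hydroxy group in the same place would help to separate. Also open, as far as these compounds go, is how a longer chain on the sulfonyl would read.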